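A few compounds are considered here, and "the series" means these few. Any claim that something is new, unique, unknown or untested is made for them only; others in the source may bear on it.

Measured in a toxicity assay on CCRF-CEM cells (Homo sapiens) for cytotoxicity; on this read-out lower numbers stand for higher toxicity in this test and higher numbers for lower toxicity in this test:
- compound 1 `Oc1cccc2c1nc(-c1c(F)cccc1F)n2Cc1c(F)cccc1F`: > 100 uM (a limit)
- compound 2 `Nc1cccc2c1nc(-c1c(F)cccc1F)n2Cc1c(F)cccc1F`: 26.3 uM
- compound 3 `CC(=O)Nc1cccc2c1nc(-c1c(F)cccc1F)n2Cc1c(F)cccc1F`: 39.3 uM

Compound 1 gives only a limit and not a number, so its place on the scale is open on one side (the limit of > 100 uM in this assay, at which 1 of the 3 values shown sits). It is the only one of the three without a measured number.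

Compound 4 `N#Cc1cccc2c1nc(-c1c(F)cccc1F)n2Cc1c(F)cccc1F` has cyano in place of hydroxy on an aromatic carbon of the core of compound 1 (cyano in place of hydroxy on an aromatic carbon). The change sits on a six-membered aromatic ring of carbon only, part of a fused or bridged system of two rings.

Among the measured compounds shown here, two measured steps bear on it. The amino in place of hydroxy step (an at least 3.8-fold lower number from compound 1 to compound 2 (0.58 log units; beyond the scatter)) and the acetamido in place of hydroxy step (an at least 2.5-fold lower number from compound 1 to compound 3 (0.40 log units; beyond the scatter)) both lie beyond the scatter, and both are bounded on one side only. The remaining step (a 1.5-fold higher number from compound 2 to compound 3 (0.17 log units; within the scatter)) lies within the scatter, so the two replacements do not separate. Neither of them is cyano, which keeps the transfer loose. On these two steps, a change of similar size towards a lower number, meaning higher toxicity, is expected in this assay for this replacement too.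

The estimated step is (an at least 2.5-fold lower number from compound 1 to compound 4 (0.39 log units; beyond the scatter)), and it remains an expectation. For compound 4 the estimated value is 40 uM with an expected range (15 uM to 100 uM).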

Compound 4, half-maximal toxic concentration: 26.7 uM
Beside the measured number, compound 4's estimate is 1.5-fold (0.18 log units) above it; low and high end bracket the measured number.
By their numbers in this assay, from the lowest: compounds 2, 4 and 3 (each within the scatter of the next). At a limit, above all of these: compound 1.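

In this assay, cyano on this aromatic carbon falls on the same side of the hydroxy compound as amino and acetamido, with an at least 3.7-fold lower number from compound 1 to compound 4 (0.57 log units; beyond the scatter), so the shift away from compound 1 also appears with a group that enters with 0 hydrogen-bond donors where hydroxy leaves with 1. The three replacements do not separate at this position: a 1.0-fold higher number from compound 2 to compound 4 (0.01 log units; within the scatter) and a 1.5-fold lower number from compound 3 to compound 4 (0.17 log units; within the scatter) both lie within the scatter, which leaves hydroxy as the only group shown that stands apart in this series. The value of compound 1 is a limit and not a number, so every step from it stays bounded on one side only: the limit of > 100 uM in this assay, at which 1 of the 4 values shown sits.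

Open, going by these compounds, is whether this separation belongs to hydroxy alone or would extend to a methoxy group, a carboxylic acid or a chlorine on the same carbon, and where a plain hydrogen there would fall relative to these four compounds. On these data alone, all four compounds also share the rest of the core of compound 1, so it remains open whether cyano, amino and acetamido would still stay together after a change elsewhere on it.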